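One Stereocentre Flipped: Will Oral Exposure Hold?

A few compounds are considered here, and "the series" means these few. Any claim that something is new, unique, unknown or untested is made for them only; others in the source may bear on it.

Of the compounds shown here, three have been measured so far in an in vivo ADME assay on the whole organism (strain Sprague-Dawley) for pharmacokinetics, with Rattus norvegicus as the target (on this read-out lower numbers stand for lower oral bioavailability and higher numbers for higher oral bioavailability), and they give a first sense of the range. Compound 1 `CN[C@@H](C)c1ccc(N2CC[C@H](NS(=O)(=O)c3ccc4cc(Cl)ccc4c3)C2=O)c(F)c1` is reported only as the limit > 10% and not as an exact number. Compound 2 `CN(C)C1CCc2cc(N3CC[C@H](NS(=O)(=O)/C=C/c4ccc(Cl)s4)C3=O)ccc21` gives 57% and compound 3 `CN(C)[C@H]1CCc2cc(N3CC[C@H](NS(=O)(=O)c4ccc5cc(Cl)ccc5c4)C3=O)ccc21` gives 61% so these two values lie within the usual scatter of each other.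

The next compound is compound 4 `CN(C)[C@@H]1CCc2cc(N3CC[C@H](NS(=O)(=O)c4ccc5cc(Cl)ccc5c4)C3=O)ccc21` and its change from compound 3 is subtle: the two compounds have the same atoms and bonds and differ only in configuration as drawn: 1 of 2 stereo elements differ; a stereocentre at a saturated ring carbon is drawn S in compound 3 and R in compound 4 and so a stereocentre at a saturated ring carbon is drawn S in compound 3 and R in compound 4. The atoms stay the same, and only their arrangement in space differs at that one carbon.

For the measured compounds named here, no measured pair yet shows what such a change does here, so the estimate starts from compound 3 and its 61% value. The expected change is small, with a number 6 percentage points lower from compound 3 to compound 4 (within the scatter) as the estimated step and no shift beyond the scatter. Compound 4 is estimated at 55% with an expected range of 30% to 75% in this measurement.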

Compound 4, oral bioavailability: 27%
Beside the measured number, compound 4's estimate is 28 percentage points above it, and the stated range ends above it.
By their numbers in this assay, from the lowest: compound 4; then compounds 2 and 3 (each within the scatter of the next).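

In this assay, for the compounds shown here, the result is a number 34 percentage points lower from compound 3 to compound 4 (beyond the scatter), and this is the first pair to show that the configuration at this saturated ring carbon matters. The S form drawn in compound 3 gives the higher number and the R form drawn in compound 4 the lower one, so the arrangement in space at one carbon can shift oral exposure in the rat without any atom changing. The drop can be traced to that carbon because nothing else separates the pair: the fact that compounds 3 and 4 differ only in the configuration as drawn.

The numbers do not show which step between dose and blood accounts for the drop. As far as these compounds go, it also remains open whether the same flip would matter as much with a primary amine in place of the dimethylamino group, or with a different sulfonyl partner.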